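The compounds below may be only part of what the source reports. "The series", "measured", "known", "first", "only" and "open" are said of these compounds alone.

Measured so far:
compound 1, `O=C(CN1CCN(c2ccncc2)CC1)Nc1nc2c(s1)CCCC2`, in an assay on isolated protein for inhibition of long-chain fatty acid transport protein 1 (Mus musculus), read by scintillation counting, with a stated time of 20 min (a lower number here means a stronger inhibitor, a higher number a weaker inhibitor), gives > 10000 nM, a limit of the assay rather than a number.
compound 2, `O=C(CN1CCN(c2ccc(F)cc2)CC1)Nc1nc2ccccc2s1`, gives > 10000 nM in this assay, again a limit.
compound 3, `O=C(CN1CCN(c2ccc(F)cn2)CC1)Nc1nc2c(o1)CCCC2`, gives 1700 nM in this assay.

For the measured compounds named here, compound 1 thus stands at the limit of > 10000 nM in this assay, at which 2 of the 3 values shown sit, so no number for it is known; compound 3 is the only member of the set with a measured value, and compound 2 sits at the same limit as compound 1. Going by the values given here, nothing in the set amounts to a single-point step between two measured compounds, so no measured step can be drawn on.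

The change from compound 1 to compound 4, `O=C(CN1CCN(c2cccnc2)CC1)Nc1nc2c(s1)CCCC2`, is pyridin-3-yl in place of pyridin-4-yl on an amine nitrogen in a ring, the remainder of the structure unchanged. With compound 1 only known as a limit, the expected step from compound 1 to compound 4 is a number no higher from compound 1 to compound 4 (the limit leaves the size open), that is, none beyond the scatter, with a fair chance that this assay again reports only a limit. Compound 4 is therefore estimated at 10000 nM, within 3000 nM to 30000 nM.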

Compound 4, half-maximal inhibitory concentration: > 10000 nM
Compound 4 ended at the assay's limit; the forecaster's own chance of this, stated with the estimate: 60%; the middle value lies on the limit itself.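

Compound 1 and compound 4 both sit at a limit of this assay, so no step can be read between them: the limit of > 10000 nM in this assay, at which 3 of the 4 values shown sit.

The compounds shown leave open whether pyridin-3-yl and pyridin-4-yl differ at all on the core of compound 1.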